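The source may hold more compounds than are shown below. What is called first, only, known or untested is meant among the compounds shown, and "the series" means these compounds.

The measured compounds:
Compound 1, `N[C@H]1CC[C@H](Nc2c(C(=O)NCc3ccccn3)nc(Br)c3cccnc23)CC1`: "not determined" (no result reported).
Compound 2, `CNCCCNc1c(C(=O)NCc2ccc(F)cc2)nc(Br)c2cccnc12`: 1000 nM.
Compound 3, `N[C@H]1CC[C@H](Nc2c(C(=O)NC3CCCCC3)nc(Br)c3cccnc23)CC1`: 4200 nM.

All three share one core. In a functional assay on SK-BR-3 cells (Homo sapiens) for cytotoxicity, read by MTT assay, with a stated time of 72 h (a higher number here means a weaker inhibitor, a lower number a stronger inhibitor), compound 2 gives 1000 nM, the lower of the two numbers available, while compound 3 gives 4200 nM, a gap beyond the usual scatter. Compound 1 offers no number for comparison. Compound 4, `CN(C)CCCNc1c(C(=O)NCc2ccc(F)cc2)nc(Br)c2cccnc12`, is not yet measured. For the measured compounds named here, its only difference from compound 2 is methyl in place of hydrogen on an amine nitrogen. Going by the values given here, no pair of measured compounds shows this particular change, so there is no measured step to lean on. With that in mind, the step of no change at the digits printed from compound 2 to compound 4 (within the scatter) is estimated to stay within the scatter, in no clear direction. Compound 4 is therefore expected to give about 1000 nM, in a range from 400 nM to 2500 nM.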

Compound 4, half-maximal inhibitory concentration: 1000 nM
Compound 4: middle estimate and measured number agree at the digits printed; low and high end bracket the measured number.
By their numbers in this assay, from the lowest: compounds 2 and 4 (each within the scatter of the next); then compound 3.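

In this assay, for the compounds shown here, the change from methylamino to dimethylamino gives no change at the digits printed from compound 2 to compound 4 (within the scatter), the first measured step at this amine nitrogen. A methyl in place of the hydrogen on this nitrogen therefore leaves the number unmoved in this cell assay, at least in this single pair. Nothing measured here bears on the reason for this result.

Still open, from the compounds shown here alone, is whether a larger group on this nitrogen, such as an ethyl or a longer chain, would also leave the number unmoved. Also open, going by these compounds, is what a carboxylic acid in place of this amine would give.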